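Chloro on the Anilino Ring: An Expected Limit Value

A few compounds are considered here, and "the series" means these few. Any claim that something is new, unique, unknown or untested is made for them only; others in the source may bear on it.

Compound 1 `COc1cc(/C=C/C(=O)c2sc(Nc3ccccc3C)nc2C)cc(OC)c1OC`: 5400 nM
Compound 2 `COc1cc(/C=C/C(=O)c2sc(Nc3ccc(Cl)c(Cl)c3)nc2C)cc(OC)c1OC`: > 25000 nM, a limit of the assay
Compound 3 `COc1cc(/C=C/C(=O)c2sc(Nc3ccccc3)nc2C)cc(OC)c1OC`: > 25000 nM, a limit of the assay

These three compounds share one core and differ only in the ring attached to the anilino nitrogen. In a functional assay on BGC-823 cells (Homo sapiens) for cytotoxicity, read by MTT assay (on this read-out higher numbers stand for weaker inhibition and lower numbers for stronger inhibition), compound 1 gives 5400 nM. The value of compound 2, > 25000 nM, is a limit of the assay and not a number. The value of compound 3, > 25000 nM, is likewise a limit. Compound 3 therefore stands at the limit of > 25000 nM in this assay, at which 2 of the 3 values shown sit, and compound 1 alone gives a measurable number.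

Compound 4 `COc1cc(/C=C/C(=O)c2sc(Nc3ccc(Cl)cc3)nc2C)cc(OC)c1OC` differs from compound 3 by chloro in place of hydrogen on an aromatic carbon. Among the compounds with values here, two measured steps bear on this change. Removing the methyl gave an at least 4.6-fold higher number from compound 1 to compound 3 (0.66 log units; beyond the scatter). Exchanging the 2-methylphenyl for a chlorine-bearing ring gave an at least 4.6-fold higher number from compound 1 to compound 2 (0.66 log units; beyond the scatter). Between the two limits themselves, a step that the two limits leave unreadable from compound 2 to compound 3. Since chlorine on the anilino ring did not bring compound 2 out of the limit, a single chloro is not expected to bring compound 4 out of it either; at best no step beyond the scatter is expected, and most likely another limit.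

Compound 4 is expected to give 30000 nM, within 10000 nM to 100000 nM. The expected step is a step that the limit leaves unreadable from compound 3 to compound 4.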

Compound 4, half-maximal inhibitory concentration: > 25000 nM
Compound 4: no number, only a limit; the forecaster's own chance of this, stated with the estimate: 70%; the middle value does not contradict the limit.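

A single chloro, para to a large group on the anilino ring, does not lift this series off the limit in this assay: compound 4 gives > 25000 nM, a limit of the assay and not a number. The steps from compound 3 to compound 4 and from compound 2 to compound 4 cannot be read, with limits at both ends, so the effect of this chloro on the phenyl ring has no measurable size here. Exchanging 2-methylphenyl for 4-chlorophenyl gives an at least 4.6-fold higher number from compound 1 to compound 4 (0.66 log units; beyond the scatter), so the only measured number shown still belongs to the ring that carries the methyl, while every other ring shown sits at the same limit: the limit of > 25000 nM in this assay, at which 3 of the 4 values shown sit.

How far the true values of compound 2, compound 3 and compound 4 lie past that limit stays open, and so does any ranking among these three compounds. Also open, as far as these compounds go, is whether a group other than methyl on the anilino ring, such as ethyl, methoxy, an amine or a carboxylic acid, would likewise give a measurable number.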